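The source may hold more compounds than are shown below. What is called first, only, known or untested is meant among the compounds shown, and "the series" means these compounds.

Measured so far in an ADME assay on T29 cells (Homo sapiens) for cytotoxicity, read by sulforhodamine B assay, with a stated time of 3 days; on this read-out higher numbers stand for weaker inhibition and lower numbers for stronger inhibition:
Compound 1 `O=Cc1cn(Cc2ccc(Cl)cc2Cl)c2ccccc12`: > 31600 nM
Compound 2 `O=Cc1cn(Cc2cccc(Cl)c2)c2ccc(F)cc12`: > 31600 nM
Compound 3 `OCc1cc2cc(F)ccc2n1Cc1ccc(Cl)cc1`: 17400 nM

Compound 1 has no exact position on this scale. In this assay compound 1 gives > 31600 nM, which is a limit of the assay and not a number. Compound 2 also carries a formyl group, and its > 31600 nM is likewise a limit. Together they make up (the limit of > 31600 nM in this assay, at which 2 of the 3 values shown sit). Only compound 3 gives a number, 17400 nM, and it differs from compound 1 in more than one place.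

The next compound is compound 4 `OCc1cn(Cc2ccc(Cl)cc2Cl)c2ccccc12`, which has hydroxymethyl in place of formyl on an aromatic carbon of the core of compound 1: hydroxymethyl in place of formyl on an aromatic carbon. Among the compounds with values here, no measured pair isolates this change, so its size can only be estimated. Within the data shown here, the expectation rests on compound 3, the only measured compound with a hydroxymethyl group, at 17400 nM. A modest estimated step of an at least 1.4-fold lower number from compound 1 to compound 4 (0.15 log units; that floor lies within the scatter) is expected, towards stronger inhibition, although a second reading at the limit would not be surprising. For compound 4 the expected value is 22000 nM, within an estimated range of 9000 nM to 45000 nM.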

Compound 4, half-maximal inhibitory concentration: > 31600 nM
Compound 4 gave a limit, no number; the forecaster's own chance of this, stated with the estimate: 45%; at least 1.4-fold (0.15 log units) between middle value and limit.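

In this assay compound 4 gives > 31600 nM, a limit of the assay and not a number. Compound 1 also stands at a limit, so no step can be read between compound 1 and compound 4: the limit of > 31600 nM in this assay, at which 3 of the 4 values shown sit. The compounds shown leave open whether hydroxymethyl in place of formyl on an aromatic carbon changes the value in this assay at all.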